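Removing the 1-Carbamoylpentyl Group from Compound 1

A few compounds are considered here, and "the series" means these few. Any claim that something is new, unique, unknown or untested is made for them only; others in the source may bear on it.

Compound 1 `CCCCC(Nc1c(C#N)c(-c2ccc(-c3ccccc3OCC)cc2)nc2cnccc12)C(N)=O` is the most lipophilic of three measured compounds in a physicochemical assay for lipophilicity, read by HPLC, at pH 7.5 (a higher number here means a more lipophilic compound, a lower number a more polar compound), where compound 1 gives 3.6. Compound 2 `CC[C@@H](Nc1c(C#N)c(-c2ccc(-c3ccccc3NC)cc2)nc2cnccc12)C(N)=O` gives 2.5 in this assay, and compound 3 `CC[C@@H](Nc1c(C#N)c(-c2ccc(-c3cccc(CO)c3)cc2)nc2cnccc12)C(N)=O` gives 2; both values lie well below that of compound 1. Among the measured compounds shown here, the only measured step between single-site neighbours, a number 0.50 log units lower from compound 2 to compound 3 (beyond the scatter), concerns a change on an aromatic carbon and says nothing about the nitrogen on the aromatic ring.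

Compound 4 `CCOc1ccccc1-c1ccc(-c2nc3cnccc3c(N)c2C#N)cc1` differs from compound 1 in exactly that place: hydrogen in place of 1-carbamoylpentyl on a nitrogen on an aromatic ring. For the measured compounds named here, no measured step bears on this change, so any expectation rests on the structural change alone. The group that leaves carries both a chain and an amide, and these pull in opposite directions on the read-out, so a modest decrease is the most plausible outcome. For compound 4 the estimate in this assay is 3.2, within a range of 2.5 to 3.9. This estimate means a step of a number 0.40 log units lower from compound 1 to compound 4 (beyond the scatter), expected to be small but noticeable.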

Compound 4, distribution coefficient: 3
For compound 4 the middle estimate is 0.20 log units above the measured one, within the range that was stated.
By their numbers in this assay, from the lowest: compound 3; then compound 2; then compound 4; then compound 1.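

In this assay, among the compounds shown here, hydrogen in place of 1-carbamoylpentyl on a nitrogen on an aromatic ring gives a number 0.60 log units lower from compound 1 to compound 4 (beyond the scatter), the first measured step at this nitrogen. It shows that this position responds to the change, and that losing the whole group, with its chain and its amide together, moves the number by only a modest amount. Nothing measured here explains the size or direction of this step.

Since the chain and the amide leave together, this single step does not separate what each of them does to the number. As far as these compounds go, how a methyl group, a shorter chain without the amide, or a carboxylic acid in place of the amide on this nitrogen would read in this assay remains open.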